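The compounds below may be only part of what the source reports. "The series", "measured", "known", "first", "only" and "open" are said of these compounds alone.

Of the compounds shown here, three sharing one core have been tested in a functional assay on MDA-MB-231 cells (Homo sapiens) for antiproliferative activity, read by MTT assay, with a stated time of 72 h; a lower number here means a stronger inhibitor, a higher number a weaker inhibitor: compound 1 `CC1=CC[C@H]2[C@H](CC[C@]2(C)O)C(C)(C)[C@@H]1CC[C@H]1[C@]2(C)CC[C@H](OC(=O)c3ccc(C)cc3)C(C)(C)O[C@H]2CC[C@@]1(C)O` gives 33400 nM, compound 2 `CC1=CC[C@H]2[C@H](CC[C@]2(C)O)C(C)(C)[C@@H]1CC[C@H]1[C@]2(C)CC[C@H](OC(=O)NCc3ccccc3)C(C)(C)O[C@H]2CC[C@@]1(C)O` gives 40300 nM, and compound 3 `CC1=CC[C@H]2[C@H](CC[C@]2(C)O)C(C)(C)[C@@H]1CC[C@H]1[C@]2(C)CC[C@H](OC(=O)c3ccc(C(F)(F)F)cc3)C(C)(C)O[C@H]2CC[C@@]1(C)O` gives 19500 nM. Compound 3 cannot be told apart from compound 1, with a 1.7-fold lower number from compound 1 to compound 3 (0.23 log units; within the scatter), but it stands apart from compound 2, with a 2.1-fold lower number from compound 2 to compound 3 (0.32 log units; beyond the scatter). Compound 4 `CC1=CC[C@H]2[C@H](CC[C@]2(C)O)C(C)(C)[C@@H]1CC[C@H]1[C@]2(C)CC[C@H](OC(=O)c3ccccc3F)C(C)(C)O[C@H]2CC[C@@]1(C)O` puts 2-fluorophenyl in place of 4-(trifluoromethyl)phenyl on a carbonyl carbon. Going by the values given here, no measured step makes this exact swap. The closest guides are those same steps and a 1.2-fold higher number from compound 1 to compound 2 (0.08 log units; within the scatter), all small, so only a small move towards a higher number is expected, namely a 1.4-fold higher number from compound 3 to compound 4 (0.14 log units; within the scatter). For compound 4 the estimated value is 27000 nM, with an expected range from 14000 nM to 50000 nM.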

Compound 4, half-maximal inhibitory concentration: 28700 nM
For compound 4 the middle estimate is 1.1-fold (0.03 log units) below the measured one; the measured number falls inside the stated range.
By their numbers in this assay, from the lowest: compounds 3, 4, 1 and 2 (each within the scatter of the next, the first and the last beyond it).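

With 2-fluorophenyl on this carbonyl carbon, compound 4 cannot be told apart from any of the other three compounds: the printed steps are a 1.5-fold higher number from compound 3 to compound 4 (0.17 log units; within the scatter) and a 1.2-fold lower number from compound 1 to compound 4 (0.07 log units; within the scatter) and also a 1.4-fold lower number from compound 2 to compound 4 (0.15 log units; within the scatter). Compounds 2 and 3 stand apart from each other, yet compound 4 lies within the scatter of both, so this position has so far tolerated all four groups shown, with no clear separation for the 2-fluorophenyl group.

As far as these compounds go, whether an amine, a carboxylic acid or a longer chain at this position would give a number clearly apart from these remains open. No available evidence accounts for these numbers.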